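Adding an ethoxy group to a slowly cleared compound

A few compounds are considered here, and "the series" means these few. Any claim that something is new, unique, unknown or untested is made for them only; others in the source may bear on it.

Compound 1 `CCn1cnc2c(-c3ccc(F)c(-c4ccc(S(=O)(=O)CC)cc4)c3)cnnc21` gives < 13 mL.min-1.g-1 
Compound 2 `CCn1cnc2c(-c3ccc(F)c(-c4ccc(C(=O)NC)cc4)c3)cnnc21` gives 16 mL.min-1.g-1 

In an ADME assay on microsomes from liver (Homo sapiens) for metabolic stability (on this read-out lower numbers stand for slow clearance and higher numbers for fast clearance), compound 1 gives < 13 mL.min-1.g-1 as a limit of the assay, not an exact number. Compound 3 `CCOc1cc(S(=O)(=O)CC)ccc1-c1cc(-c2cnnc3c2ncn3CC)ccc1F` differs from compound 1 in one place, with ethoxy in place of hydrogen on an aromatic carbon as the whole change. Among the compounds with values here, no measured step adds a group at this place. Within the data shown here, the sole guide is an at least 1.2-fold higher number from compound 1 to compound 2 (0.09 log units; that floor lies within the scatter) and it bears only loosely on this change: the ethylsulfonyl group replaced there stays in compound 3. On that small step, a modest rise in this assay is expected, and it may stay within the scatter. The estimated size of the change is an at least 1.3-fold higher number from compound 1 to compound 3 (0.14 log units; that floor lies within the scatter) and no more than a rough guide. For compound 3 the expected value is 18 mL.min-1.g-1 with an estimated range of 9 mL.min-1.g-1 to 36 mL.min-1.g-1 in repeated measurements.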

Compound 3, intrinsic clearance in microsomes in the Homo sapiens assay: 12 mL.min-1.g-1
Estimate against measurement, compound 3: 1.5-fold (0.18 log units) above, and the stated range covers the measured number.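

In the Homo sapiens assay compound 1 gives < 13 mL.min-1.g-1 as a limit of the assay and not a number. In the Homo sapiens assay compound 3 gives 12 mL.min-1.g-1 as a measured number. The step from compound 1 to compound 3 therefore cannot be read. The compounds shown leave open whether ethoxy in place of hydrogen on an aromatic carbon changes the clearance at all. In a physicochemical assay for lipophilicity (a higher number here means a more lipophilic compound, a lower number a more polar compound), compound 1 gives 2.9 and compound 3 gives 3.3 as measured numbers. In the physicochemical assay ethoxy in place of hydrogen on an aromatic carbon gives a number 0.40 log units higher from compound 1 to compound 3 (beyond the scatter) as its step.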